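Series notes: phenyl for cyclopropyl on the side chain

The source may report more compounds than this note shows. Statements on the series, on what has been measured and on what is new or still open speak of the compounds shown alone.

Three compounds of the shared core have been run in an in vitro functional assay on cells for agonist activity at Bombesin receptor subtype-3 (Mus musculus), read by luminescence and calcium flux; on this read-out lower numbers stand for an effect already at smaller amounts and higher numbers for an effect only at larger amounts of compound. Compound 1 `O=C(O)c1ccccc1-c1ccc(CCc2ncc(Cc3ccc(Cl)cc3)[nH]2)cc1` gives 102 nM. Compound 2 `O=C(O)c1ccccc1-c1ccc(CCc2ncc(CCC3CCCCC3)[nH]2)cc1` gives 33 nM. Compound 3 `O=C(O)c1ccccc1-c1ccc(CCc2ncc(CC3CC3)[nH]2)cc1` gives 72 nM, which places compound 3 second highest of the three numbers, nearest to compound 1 and furthest from compound 2: a 1.4-fold lower number from compound 1 to compound 3 (0.15 log units; within the scatter), while a 2.2-fold higher number from compound 2 to compound 3 (0.34 log units; beyond the scatter).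

Compound 4 `O=C(O)c1ccccc1-c1ccc(CCc2ncc(Cc3ccccc3)[nH]2)cc1` is not yet measured. The change is phenyl in place of cyclopropyl on a saturated chain carbon bound to an aromatic carbon. Among the measured compounds shown here, two measured steps bear on it. The first, a 1.4-fold lower number from compound 1 to compound 3 (0.15 log units; within the scatter), runs the present change in reverse apart from the difference between 4-chlorophenyl and phenyl; the second, a 2.2-fold higher number from compound 2 to compound 3 (0.34 log units; beyond the scatter), is the other step into compound 3. For the measured compounds named here, no measured pair sets phenyl beside 4-chlorophenyl in this place, so that part of the change is unknown. A small step back toward the number of compound 1 is expected, possibly within the scatter. The expected step in this assay is a 1.5-fold higher number from compound 3 to compound 4 (0.18 log units; within the scatter). Compound 4 is estimated at 110 nM, with a range of 45 nM to 270 nM.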

Compound 4, half-maximal effective concentration: 11 nM
Compound 4: middle estimate off by 10-fold (1.00 log units), on the high side, outside the stated range (below it).
By their numbers in this assay, from the lowest: compound 4; then compound 2; then compounds 3 and 1 (each within the scatter of the next).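

Against the saturated groups there is a 6.5-fold lower number from compound 3 to compound 4 (0.82 log units; beyond the scatter) and a 3.0-fold lower number from compound 2 to compound 4 (0.48 log units; beyond the scatter) at this place on a saturated chain carbon bound to an aromatic carbon, so benzyl gives the lowest number of the four in this assay and neither saturated group matches it. Hydrogen in place of chloro on an aromatic carbon gives a 9.3-fold lower number from compound 1 to compound 4 (0.97 log units; beyond the scatter) in one step, so the earlier closeness of compound 1 and compound 3 said little about benzyl itself: the phenyl ring without chloro behaves quite differently from 4-chlorophenyl here. No measurement at hand gives a reason for these steps.

On these data alone, whether other groups on that phenyl raise the number as chloro does stays open; fluoro, methyl or methoxy would test this. Also open, as far as these compounds go, is how phenethyl, a longer chain carrying the phenyl, compares with benzyl.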